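A few compounds are considered here, and "the series" means these few. Any claim that something is new, unique, unknown or untested is made for them only; others in the source may bear on it.

Measured compounds in an assay on BaF3 cells for inhibition of proto-oncogene tyrosine-protein kinase receptor Ret variant V804M (Homo sapiens), read by MTT assay, with a stated time of 48 h; a higher number here means a weaker inhibitor of growth, a lower number a stronger inhibitor of growth:
compound 1 `CC(C)n1nc(-c2cc(C3CCCCC3)on2)c2c(N)ncnc21` gives 4730 nM
compound 2 `CC(C)n1nc(-c2ccon2)c2c(N)ncnc21` gives 8940 nM
compound 3 `CC(C)n1nc(/C=N/O)c2c(N)ncnc21` gives > 10000 nM, a limit of the assay (the limit of > 10000 nM in this assay, at which 1 of the 3 values shown sits).

Compound 2 stands at the highest of the two numbers shown; its only neighbour is compound 1, and the step of a 1.9-fold higher number from compound 1 to compound 2 (0.28 log units; within the scatter) is within the scatter. The step of an at least 1.1-fold higher number from compound 2 to compound 3 (0.04 log units; that floor lies within the scatter) ends at a limit and adds little.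

Compound 4 `CC(C)n1nc(-c2cc(-c3ccccc3)on2)c2c(N)ncnc21` has not yet been measured in this assay. The change from compound 2 to compound 4 is phenyl in place of hydrogen on an aromatic carbon. Going by the values given here, the one measured step that bears on it is the step from compound 1 to compound 2, where a larger ring group at the same aromatic carbon went with a number lower by an amount within the scatter. Phenyl is a ring group of comparable size to cyclohexyl, so compound 4 is expected to move back toward compound 1, by a step of a 2.0-fold lower number from compound 2 to compound 4 (0.30 log units; within the scatter) that likely stays within the scatter. Compound 4 is therefore estimated at 4500 nM, between 1500 nM and 12000 nM.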

Compound 4, concentration for 50% growth inhibition: 4970 nM
Compound 4: middle estimate off by 1.1-fold (0.04 log units), on the low side, within the range that was stated.
By their numbers in this assay, from the lowest: compounds 1, 4 and 2 (each within the scatter of the next). At a limit, above all of these: compound 3.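

In this assay, the step with phenyl in place of hydrogen is a 1.8-fold lower number from compound 2 to compound 4 (0.25 log units; within the scatter), so a flat aromatic ring of carbon only on this carbon, next to the ring oxygen, cannot be told apart from hydrogen, just as cyclohexyl could not. The new comparison of the two ring groups is a 1.1-fold higher number from compound 1 to compound 4 (0.02 log units; within the scatter), which shows that at this position phenyl and cyclohexyl cannot be told apart either. Nothing shown here gives a reason for these numbers.

Every group shown on this carbon beyond hydrogen is a ring of carbon only, so it stays open whether an amine, a carboxylic acid or a longer chain there would move the number beyond the scatter. On these data alone, it is equally open whether a fluorine or a methoxy group on the phenyl itself would do so.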